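This account rests on a few compounds, and the source may have more. Where it says the series, first, only, none or still open, it means among the compounds named here.

Measured compounds:
- compound 1 `Cc1nc(N)sc1CCCN/C(N)=N/C(=O)NCC(C)C1CCCCC1`; in a functional assay on HEK293T cells for agonist activity at histamine H2 receptor (Homo sapiens), read by beta-arrestin recruitment (a lower number here means that less compound is needed, a higher number that more compound is needed for the effect), compound 1 gives 224 nM
- compound 2 `Cc1nc(N)sc1CCCN/C(N)=N/C(=O)NCc1ccccc1`; in this assay compound 2 gives 100 nM

Among the two numbers so far, compound 1 stands highest, and its nearest neighbour is compound 2, reached by a 2.2-fold lower number from compound 1 to compound 2 (0.35 log units; beyond the scatter). The unmeasured compound 3 `Cc1nc(N)sc1CCCN/C(N)=N/C(=O)NCC(C)CCCc1ccccc1` keeps the shared core and the methyl-bearing chain of compound 1 and changes only the end of that chain: 3-phenylpropyl in place of cyclohexyl on a saturated chain carbon bound to two saturated chain carbons.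

Going by the values given here, only one measured step bears on this change, and only loosely. The step of a 2.2-fold lower number from compound 1 to compound 2 (0.35 log units; beyond the scatter) replaced a saturated ring and its linker with a bare aromatic ring and gave a modest lowering. Compound 3 instead keeps a three-carbon linker and swaps the saturated ring for an aromatic one, so the change is smaller in character than that step. A step of about that size or none beyond the scatter is therefore expected in this assay, with the direction most likely downward, as a 1.5-fold lower number from compound 1 to compound 3 (0.17 log units; within the scatter).

Compound 3 is estimated to give 150 nM in this assay, within a range from 60 nM to 400 nM.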

Compound 3, half-maximal effective concentration: 2510 nM
Compound 3: the middle estimate sits 17-fold (1.22 log units) below what was measured, and the stated range ends below it.
By their numbers in this assay, from the lowest: compound 2; then compound 1; then compound 3.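

In this assay, going by these compounds alone, the end of the methyl-bearing chain turns out to matter far more than the earlier compounds suggested. Placing 3-phenylpropyl in place of cyclohexyl on a saturated chain carbon bound to two saturated chain carbons gives a large step upward (an 11-fold higher number from compound 1 to compound 3 (1.05 log units; beyond the scatter)), whereas the only earlier step was modest and downward (a 2.2-fold lower number from compound 1 to compound 2 (0.35 log units; beyond the scatter)), so an aromatic ring at the far end of a substituent does not by itself bring a lower number, and this position does not tolerate every enlargement of the group. Nothing measured on these compounds accounts for the size or direction of the new step.

The change brings in an aromatic ring and a propyl chain together, which leaves open whether the rise follows the ring, the chain or the two in combination; a 3-cyclohexylpropyl group or a phenyl group directly in place of cyclohexyl would separate them. Also open, going by these compounds, is whether a shorter link, such as a benzyl or 2-phenylethyl group at this carbon, would give a number nearer that of compound 1 or a still higher one.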